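A few compounds are considered here, and "the series" means these few. Any claim that something is new, unique, unknown or untested is made for them only; others in the source may bear on it.

Working notes on the series.

Compound 3 `Nc1nc(=O)n(C2OC(CO)C(Br)C2O)cc1F` and compound 1 `Nc1ccn(C2OC(CO)C(Br)C2O)c(=O)n1` share one core and differ in a single place; compound 2 `CS(=O)(=O)O[C@@H]1[C@@H](O)[C@H](n2cc(F)c(N)nc2=O)O[C@@H]1CO` and compound 4 `CS(=O)(=O)O[C@@H]1[C@@H](O)[C@H](n2ccc(N)nc2=O)O[C@@H]1CO` share a second core. How the two cores differ is not broken down here.

In a functional assay on L5178Y cells (Mus musculus) for antiproliferative activity (a higher number here means a weaker inhibitor, a lower number a stronger inhibitor), compound 3 gives 2.6 ug/mL. For compound 1 this assay reports only a limit, > 100 ug/mL. Compound 2 gives 5.3 ug/mL in this assay, standing a little higher than compound 3.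

Within the data shown here, the one measured step, (hydrogen in place of fluoro on an aromatic carbon), gives an at least 38-fold higher number from compound 3 to compound 1 (1.58 log units; beyond the scatter); its size is open at the top because of the limit of > 100 ug/mL in this assay, at which 1 of the 3 values shown sits.

The same kind of change separates compound 2 from compound 4, (hydrogen in place of fluoro on an aromatic carbon), though the surroundings are not identical: on the first core the changed carbon sits meta to a group of 9 heavy atoms, on the second core meta to a large group.

Expectation for compound 4 rests on compound 3 and the step of an at least 38-fold higher number from compound 3 to compound 1 (1.58 log units; beyond the scatter): a loss of the same order, a 28-fold higher number from compound 2 to compound 4 (1.45 log units; beyond the scatter), is expected. Compound 4 is accordingly estimated at 150 ug/mL, between 30 ug/mL and 800 ug/mL, with a real chance that this assay again returns only a limit.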

Compound 4, concentration for 50% inhibition: > 100 ug/mL
Compound 4 ended at the assay's limit; the forecaster's own chance of this, stated with the estimate: 65%; the middle value does not contradict the limit.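

Hydrogen in place of fluoro on an aromatic carbon gives an at least 18-fold higher number from compound 2 to compound 4 (1.27 log units; beyond the scatter) in this assay, so the large loss seen on the first core recurs on the second and the direction of the change carries across these two cores. Set side by side, the two steps give no comparison of size: the same change on two cores in this assay, an at least 38-fold higher number (1.58 log units; beyond the scatter) from compound 3 to compound 1 and an at least 18-fold higher number (1.27 log units; beyond the scatter) from compound 2 to compound 4; the limit leaves it open whether they differ

Both steps end at the limit of the assay, so neither gives the full size of the loss, and two cores do not show that the change would carry to any further core.

The compounds shown hold only fluoro or hydrogen at this ring carbon, which leaves open how a chloro or a methyl group would read there on either core. Also open, from the compounds shown here alone, is whether the step from fluoro to hydrogen would keep its direction with a hydroxyl group in place of the amino group.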